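The source may report more compounds than this note shows. Statements on the series, on what has been measured and on what is new or still open speak of the compounds shown alone.

Measured compounds:
compound 1 `COc1ccc(CNC(=O)c2cc(-c3cncc(C)c3)ncc2-c2cncc(F)c2)nc1OC`: 5.2 nM
compound 2 `COc1ccc(CNC(=O)c2sc(-c3cncc(C)c3)nc2-c2cccc(F)c2)nc1OC`: 140 nM

In an assay on CHO cells for displacement of a labelled ligand from Orexin receptor type 2 (Homo sapiens), read by scintillation counting, with a stated time of 3 h (a higher number here means a weaker inhibitor, a lower number a stronger inhibitor), compound 1 gives 5.2 nM, the lowest of the two numbers. Compound 2 gives 140 nM in this assay, a much higher number, beyond the scatter. Compound 3 `COc1ccc(CNC(=O)c2cc(-c3cncc(C)c3)ncc2-c2ccccc2F)nc1OC` is not yet measured. It differs from compound 1 in one place: 2-fluorophenyl in place of 5-fluoropyridin-3-yl on an aromatic carbon. Within the data shown here, no pair of measured compounds shows this change on its own, so its effect can only be estimated. The step is expected to be a modest weakening, a 2.9-fold higher number from compound 1 to compound 3 (0.46 log units; beyond the scatter), small but beyond the scatter. Compound 3 is therefore expected to give about 15 nM, in the range 4 nM to 60 nM.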

Compound 3, inhibition constant: 1.4 nM
Compound 3: middle estimate off by 11-fold (1.03 log units), on the high side; the measured number lies below the stated range.
By their numbers in this assay, from the lowest: compound 3; then compound 1; then compound 2.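

In this assay, this aromatic carbon accepts a ring of carbon only: 2-fluorophenyl in place of 5-fluoropyridin-3-yl gives a 3.7-fold lower number from compound 1 to compound 3 (0.57 log units; beyond the scatter), so the ring nitrogen of the leaving group is not needed for a low number here. The change removes that nitrogen and also shifts the fluorine, and the step reflects both together. Nothing measured accounts for the step. The compounds shown leave open which of the two changes matters, and whether unsubstituted phenyl, 2-chlorophenyl or 2-methoxyphenyl would serve equally well at this position.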